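This account rests on a few compounds, and the source may have more. Where it says the series, first, only, none or still open, it means among the compounds named here.

Series notes. Compound 2 `C1=C(c2cccnc2)C[C@H]2CNC[C@@H]1C2` gives 0.95 nM in an in vitro assay on HEK-293T cells for displacement of a labelled ligand from Neuronal acetylcholine receptor; alpha3/alpha6/beta2/beta3 (Homo sapiens); on this read-out lower numbers stand for stronger inhibition and higher numbers for weaker inhibition. Compound 1 `CN1C[C@H]2C=C(c3cccnc3)C[C@H](C2)C1` carries methyl in place of hydrogen on an amine nitrogen in a ring and in this assay compound 1 gives 300 nM; the step of a 320-fold higher number from compound 2 to compound 1 (2.50 log units; beyond the scatter) is the only measured case of this change. Compound 3 `CC(C)Oc1cncc(C2=CC3CNCC(C2)C3)c1` differs from compound 2 in the substituted pyridine part; the difference between the two cores is not broken down here. In this assay compound 3 gives 2.6 nM, a higher number than compound 2 and a far lower one than compound 1. Compound 4 `CC(C)Oc1cncc(C2=CC3CC(C2)CN(C)C3)c1` carries the same change, (methyl in place of hydrogen on an amine nitrogen in a ring), at a place described identically. Because a 320-fold higher number from compound 2 to compound 1 (2.50 log units; beyond the scatter) is large, the step of a 190-fold higher number from compound 3 to compound 4 (2.28 log units; beyond the scatter) is expected to be of comparable size, although a single precedent leaves room for a smaller or larger shift. Compound 4 is therefore estimated at 500 nM, with a range from 100 nM to 2500 nM.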

Compound 4, inhibition constant: 690 nM
Estimate against measurement, compound 4: 1.4-fold (0.14 log units) below, and the stated range covers the measured number.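

In this assay, methyl in place of hydrogen on an amine nitrogen in a ring gives a 270-fold higher number from compound 3 to compound 4 (2.42 log units; beyond the scatter), and the size of the step carries over from the core of compound 2 to the core of compound 3: the same change on two cores in this assay, a 320-fold higher number (2.50 log units; beyond the scatter) from compound 2 to compound 1 and a 270-fold higher number (2.42 log units; beyond the scatter) from compound 3 to compound 4, 1.2-fold (0.08 log units) apart, within the scatter of two such steps. Among the compounds shown here, this rests on only two pairs, which differ from each other in the substituted pyridine part, so it supports transfer across that one difference and not to cores that differ elsewhere. The numbers also do not show why the methyl has this effect.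

Still open, from the compounds shown here alone, is whether a longer chain such as ethyl, or a benzyl or acetyl group, on the same nitrogen gives a step of similar size. Also open, going by these compounds, is whether the step holds with a nitrile or an amine on the pyridine in place of the isopropoxy group.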